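From compound 2 to compound 3: one group exchanged

The compounds below may be only part of what the source reports. "The series", "measured", "known", "first", "only" and "open" are said of these compounds alone.

Of the compounds shown here, two with a shared core have been measured so far in an ADME assay on HEp-2 cells (Homo sapiens) for cytotoxicity; on this read-out higher numbers stand for lower toxicity in this test and lower numbers for higher toxicity in this test. Compound 1 (`Cc1cccc(NC(=O)[C@@H]2CCCN2S(=O)(=O)c2cccc3cccnc23)c1`) gives 25500 nM, and compound 2 (`Cc1ccc(C(C)C)cc1NC(=O)[C@@H]1CCCN1S(=O)(=O)c1cccc2cccnc12`) gives 9700 nM, the lower of the two numbers. Compound 3 (`COc1ccc(C)cc1NC(=O)[C@@H]1CCCN1S(=O)(=O)c1cccc2cccnc12`) has not yet been measured. It keeps the shared core but carries 2-methoxy-5-methylphenyl in place of 5-isopropyl-2-methylphenyl on an amide-type nitrogen.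

Going by the values given here, only one measured step bears on this change. When 5-isopropyl-2-methylphenyl replaced 3-methylphenyl on that nitrogen, the result was a 2.6-fold lower number from compound 1 to compound 2 (0.42 log units; beyond the scatter), a modest step. Compound 3 loses that same 5-isopropyl-2-methylphenyl group, so part of this step may be reversed. Among the compounds with values here, a single step is thin evidence, however, and no measured compound yet carries 2-methoxy-5-methylphenyl. A modest move toward a higher number in this assay is therefore expected, namely a 2.2-fold higher number from compound 2 to compound 3 (0.34 log units; beyond the scatter). The estimated value for compound 3 is 21000 nM, with an expected range of 9000 nM to 48000 nM.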

Compound 3, half-maximal cytotoxic concentration: > 50000 nM
Compound 3: no number, only a limit; the forecaster's own chance of this, stated with the estimate: 10%; middle value at least 2.3-fold (0.37 log units) away from the limit.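

Compound 3 gives no number in this assay, only a limit of the assay: the limit of > 50000 nM in this assay, at which 1 of the 3 values shown sits.

Even with that limit, exchanging 5-isopropyl-2-methylphenyl for 2-methoxy-5-methylphenyl on the amide-type nitrogen gives an at least 5.1-fold higher number from compound 2 to compound 3 (0.71 log units; beyond the scatter), so the lower number of compound 2 does not extend to every substituted phenyl group at this place. Measured against the simpler 3-methylphenyl group, methoxy in place of hydrogen on an aromatic carbon gives an at least 1.9-fold higher number from compound 1 to compound 3 (0.29 log units; that floor lies within the scatter), which means compound 3 cannot be firmly separated from compound 1 on this read-out, although the methoxy-bearing ring shows no sign of a lower number.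

From the compounds shown here alone, the true size of both steps remains unknown, and the exchange from compound 2 to compound 3 alters the ring in more than one way, so the part played by the methoxy cannot be told from the part played by the isopropyl. Going by these compounds, it also remains open whether an ethoxy group or a dimethylamino group in place of the methoxy would give a measurable number in this assay.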